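The source may report more compounds than this note shows. Statements on the series, on what has been measured and on what is new or still open speak of the compounds shown alone.

Measured so far in an ADME assay on HUVEC cells (Homo sapiens) for cytotoxicity, read by MTT assay, with a stated time of 2 days; a higher number here means a weaker inhibitor, a lower number a stronger inhibitor:

compound 1 `c1ccc(CO/N=C2/C(c3c[nH]c4ccccc34)=Nc3ccccc32)cc1` gives > 100000 nM, which is a limit of the assay rather than a number.
compound 2 `Fc1ccc2c(c1)/C(=N\OCc1ccccc1)C(c1c[nH]c3ccc(F)cc13)=N2` gives > 100000 nM, again a limit.
compound 3 `FC(F)(F)c1ccc(CO/N=C2/C(c3c[nH]c4ccc(Br)cc34)=Nc3ccc(Br)cc32)cc1` gives > 100000 nM, again a limit.

Compound 1 thus stands at the same place as every other value seen here: the limit of > 100000 nM in this assay, at which 3 of the 3 values shown sit. Within the data shown here, no step between two measured compounds can be read off, since none of the three has a number.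

Compound 4 `Fc1ccc(CO/N=C2/C(c3c[nH]c4ccccc34)=Nc3ccccc32)c(Cl)c1` differs from compound 1 by 2-chloro-4-fluorophenyl in place of phenyl on a saturated chain carbon bound to an oxygen on an unsaturated carbon. With all three measured compounds sitting at the limit, the step from compound 1 to compound 4 is expected to be none beyond the scatter: a step that the limit leaves unreadable from compound 1 to compound 4. For compound 4 the estimate is therefore 200000 nM, with a range from 100000 nM to 500000 nM, and most likely this assay will again report only a limit.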

Compound 4, half-maximal inhibitory concentration: > 100000 nM
Compound 4: no number, only a limit (the forecaster's own chance of this, stated with the estimate: 90%); the middle value does not contradict the limit.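

Compound 1 and compound 4 each give only a limit, so no step between them can be read: the limit of > 100000 nM in this assay, at which 4 of the 4 values shown sit.

As far as these compounds go, whether any compound of this kind would give an actual number in this assay stays open.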